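The compounds below may be only part of what the source reports. "The series", "measured", "known", "first", "only" and "open" are said of these compounds alone.

Compound 3 `COc1ccc(/C=C/C(=O)c2ccccc2NC(=O)NS(=O)(=O)c2ccc(C)cc2)cc1OC` gives 12.9 ug/mL in an ADME assay on the whole organism for cytotoxicity, with Artemia salina as the target, with a stated time of 24 h (on this read-out higher numbers stand for an effect only at larger amounts of compound and lower numbers for an effect already at smaller amounts), the lowest of the three numbers at hand. Compound 1 `COc1cccc(/C=C/C(=O)c2ccccc2NC(=O)NS(=O)(=O)c2ccc(C)cc2)c1` gives 23.2 ug/mL in this assay, and compound 2 `COc1ccc(/C=C/C(=O)c2ccccc2NC(=O)NS(=O)(=O)c2ccc(C)cc2)cc1` gives 28.1 ug/mL. The step of a 1.8-fold lower number from compound 1 to compound 3 (0.25 log units; within the scatter) stays within the scatter, while the step of a 2.2-fold lower number from compound 2 to compound 3 (0.34 log units; beyond the scatter) is a modest one beyond it, so compound 3 cannot be called stronger than compound 1.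

Compound 4 `COc1ccc(/C=C/C(=O)c2ccccc2NC(=O)NS(=O)(=O)c2ccc(C)cc2)c(OC)c1` differs from compound 3 in one place: 2,4-dimethoxyphenyl in place of 3,4-dimethoxyphenyl on a double-bonded chain carbon bound to a double-bonded chain carbon. The two have the same atoms, joined differently; one methoxy group is shifted on the phenyl. The most closely related measured step is a 1.2-fold higher number from compound 1 to compound 2 (0.08 log units; within the scatter), which also shifted a single methoxy group on the phenyl and stayed within the scatter. The steps of a 1.8-fold lower number from compound 1 to compound 3 (0.25 log units; within the scatter) and a 2.2-fold lower number from compound 2 to compound 3 (0.34 log units; beyond the scatter) added a methoxy group rather than moving one, so they bear on this change only loosely. The step of a 1.2-fold higher number from compound 3 to compound 4 (0.09 log units; within the scatter) is therefore expected to stay within the scatter, leaning if anything toward a higher number. The estimate for compound 4 in this assay is 16 ug/mL, within a range from 8 ug/mL to 32 ug/mL.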

Compound 4, concentration for half-maximal effect: 16 ug/mL
The estimate for compound 4 equals the measured number at the digits printed; the range from low to high includes it.
By their numbers in this assay, from the lowest: compounds 3, 4, 1 and 2 (each within the scatter of the next, the first and the last beyond it).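

The shift of one methoxy group on the phenyl, from 3,4-dimethoxyphenyl to 2,4-dimethoxyphenyl, stays within the scatter in this assay (a 1.2-fold higher number from compound 3 to compound 4 (0.09 log units; within the scatter)), as did the earlier shift from 3-methoxyphenyl to 4-methoxyphenyl. Within the data shown here, compound 4 also lies within the scatter of both compounds with a single methoxy group (a 1.8-fold lower number from compound 2 to compound 4 (0.24 log units; within the scatter)) and (a 1.5-fold lower number from compound 1 to compound 4 (0.16 log units; within the scatter)), so the one step beyond the scatter, from compound 2 to compound 3, finds no counterpart in compound 4. Methoxy in place of hydrogen on an aromatic carbon gives closely matching steps on two cores: the same change on two cores in this assay, a 1.8-fold lower number (0.25 log units; within the scatter) from compound 1 to compound 3 and a 1.8-fold lower number (0.24 log units; within the scatter) from compound 2 to compound 4, 1.0-fold (0.01 log units) apart, within the scatter of two such steps.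

On these data alone, the phenyl in all four compounds carries only methoxy groups, so the effect of any other substituent there remains open. Whether a hydroxy group, a chlorine atom or a dimethylamino group on this phenyl would move the number beyond the scatter also remains unanswered.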